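Swapping the anilino ring on a weak antiproliferative scaffold

A few compounds are considered here, and "the series" means these few. Any claim that something is new, unique, unknown or untested is made for them only; others in the source may bear on it.

Compound 1 `Cc1cc(F)ccc1Nc1ncc(C(F)(F)F)c(N2Cc3cccc(N(C)S(C)(=O)=O)c3C2)n1` was tested in a functional assay on OVCAR-3 cells (Homo sapiens) for antiproliferative activity, read by spectrophotometry, with a stated time of 2 days; on this read-out lower numbers stand for stronger inhibition of growth and higher numbers for weaker inhibition of growth. In this assay compound 1 gives > 30000 nM, which is a limit of the assay rather than a number. Compound 1 therefore stands at the limit of > 30000 nM in this assay, at which 1 of the 2 values shown sits. Its companion compound 2 `CN(c1cccc2c1CN(c1nc(Nc3cccc(Oc4ccccc4)c3)ncc1C(F)(F)F)C2)S(C)(=O)=O` carries a different aryl group on the same nitrogen of the shared core; in this assay compound 2 gives 24900 nM. Both measured compounds thus sit at the weak end of what the assay reports.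

Compound 3 `CN(c1cccc2c1CN(c1nc(Nc3cc(Cl)cc(C(F)(F)F)c3)ncc1C(F)(F)F)C2)S(C)(=O)=O` has not yet been measured. It differs from compound 1 in one place: 3-chloro-5-(trifluoromethyl)phenyl in place of 4-fluoro-2-methylphenyl on a nitrogen on an aromatic ring. Among the measured compounds shown here, no measured step between two compounds that differ in a single place is available, so the expectation rests on the weak results of compound 1 and compound 2 alone. Replacing the aryl group on that nitrogen is not expected to move the read-out beyond the usual scatter in either direction. The expected step is an at least 1.2-fold lower number from compound 1 to compound 3 (0.07 log units; that floor lies within the scatter). Compound 3 is estimated at 25000 nM, with a range from 8000 nM to 60000 nM, and a fair chance that the assay again reports only a limit.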

Compound 3, concentration for 50% growth inhibition: 21500 nM
Compound 3: the middle estimate sits 1.2-fold (0.07 log units) above what was measured, within the range that was stated.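

Compound 3 turns a limit into a measured number for this position: with 3-chloro-5-(trifluoromethyl)phenyl in place of 4-fluoro-2-methylphenyl on the nitrogen, this assay shows an at least 1.3-fold lower number from compound 1 to compound 3 (0.14 log units; that floor lies within the scatter). That step has only a floor, because compound 1 stands at a limit of the assay, so its true size cannot be read: the limit of > 30000 nM in this assay, at which 1 of the 3 values shown sits.

With this new aryl group compound 3 gives 21500 nM, and compound 2 gives 24900 nM, so both of these aryl groups leave the shared core at the weak end of what the read-out reports, and this change alone does not lift it out of that region.

What the compounds shown leave open is whether any group on this nitrogen can give a strong number, for instance an aryl ring that carries an amine or a carboxylic acid. They also do not tell whether a change elsewhere on the shared core, such as a nitrile in place of its trifluoromethyl group, would move the number at all.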